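A few compounds are considered here, and "the series" means these few. Any claim that something is new, unique, unknown or untested is made for them only; others in the source may bear on it.

Working notes on the series.

Of the compounds shown here, two have numbers so far. Compound 1 `COc1cc(-c2cc(/C=C/C(=O)c3ccc(Cl)c(Cl)c3)[nH]n2)cc(OC)c1OC` gives 99% in a functional assay on SK-MEL-2 cells (Homo sapiens) for cytotoxicity, read by sulforhodamine B assay, with a stated time of 48 h, tested at 1 uM; a higher number here means a weaker effect of the compound at the concentration tested, a lower number a stronger effect. Compound 2 `COc1ccc(C(=O)/C=C/c2cc(-c3cc(OC)c(OC)c(OC)c3)n[nH]2)cc1OC` gives 98% in this assay. Among the compounds with values here, the one measured step, a number 1 percentage points lower from compound 1 to compound 2 (within the scatter), leaves compound 2 with the lowest of the two numbers, but its gap to compound 1 lies within the scatter, so no order between them can be read.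

Compound 3 `COc1ccc(C(=O)/C=C/c2cc(-c3cc(OC)c(OC)c(OC)c3)n[nH]2)cc1` is the next member. It differs from compound 2 by hydrogen in place of methoxy on an aromatic carbon. Within the data shown here, no measured step removes a methoxy group from this ring; the only step available, a number 1 percentage points lower from compound 1 to compound 2 (within the scatter), touched this ring and showed nothing beyond the scatter. Both measured numbers sit near the top of the scale. The expectation for compound 3 is therefore a step of a number 1 percentage points lower from compound 2 to compound 3 (within the scatter), no change beyond the scatter. Compound 3 is estimated at 97%, between 85% and 104%.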

Compound 3, a percentage reported as activity, at one concentration (the size of the read-out at that concentration, not a potency): 97%
Estimate against measurement, compound 3: no gap at the digits printed; the measured number falls inside the stated range.
By their numbers in this assay, from the lowest: compounds 3, 2 and 1 (each within the scatter of the next).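

In this assay, within the data shown here, this is the first reading of a single methoxy group at this position: hydrogen in place of methoxy, ortho to a methoxy group, gives no readable difference (a number 1 percentage points lower from compound 2 to compound 3 (within the scatter)). The wider exchange of 3,4-dichlorophenyl for 4-methoxyphenyl on the carbonyl carbon likewise gives no order between its two compounds (a number 2 percentage points lower from compound 1 to compound 3 (within the scatter)), so all three compounds remain together near the top of the scale. No measured evidence bears on this result.

Every number sits within the scatter of the others. The series does not yet show whether this ring can influence the read-out at all. Still open, on these data alone, is what a dimethylamino group or a carboxylic acid on this ring would give, or hydrogen in place of the remaining methoxy group.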